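Methoxy for Hydrogen on a Dichloroacetamide Series

The source may report more compounds than this note shows. Statements on the series, on what has been measured and on what is new or still open speak of the compounds shown alone.

Measured compounds:
- compound 1 `O=C(Nc1ccccc1)C(Cl)Cl`: "not determined" (no result reported)
- compound 2 `O=C(Nc1ccccc1F)C(Cl)Cl`: "not determined" (no result reported)
- compound 3 `O=C(Nc1cccc(Br)c1)C(Cl)Cl`: 7720 nM

Compound 1 has no number to stand on. In a functional assay on Bel-7402 cells (Homo sapiens) for antiproliferative activity, read by MTT assay, with a stated time of 72 h (on this read-out higher numbers stand for weaker inhibition and lower numbers for stronger inhibition), compound 1 gives "not determined" (no result reported), and compound 2, which carries a fluorine on the same shared core, also gives "not determined" (no result reported). Among the compounds with values here, the only firm point is compound 3, which in this assay gives 7720 nM, a weak inhibition. Within the data shown here, two of the three measured compounds therefore show nothing at all, and no step between any two measured compounds can be drawn; the series offers a single number and no trend.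

Compound 4 `COc1ccc(NC(=O)C(Cl)Cl)cc1` differs from compound 1 by one change: methoxy in place of hydrogen on an aromatic carbon. Among the measured compounds shown here, with no measured step to lean on, the expectation for this change in this assay is a step no larger than the usual scatter, in no clear direction, with weak inhibition in the region where compound 3 already sits. On that footing, compound 4 is estimated to give 10000 nM in this assay, with a range from 3000 nM to 40000 nM, and there is a real chance that only a limit is reported.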

Compound 4, half-maximal inhibitory concentration: 192000 nM
Compound 4: middle estimate off by 19-fold (1.28 log units), on the low side, and the stated range ends below it.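

Within the data shown here, compound 1 has no number in this assay, so compound 4, at 192000 nM, cannot be set against it, and no step for methoxy in place of hydrogen can be read. The compounds shown leave open whether this change moves inhibition at all, and in which direction. Nothing shown explains the value of compound 4.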